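The source may report more compounds than this note shows. Statements on the series, on what has been measured and on what is new or still open speak of the compounds shown alone.

Measured compounds:
- compound 1 `O=C(O)c1cccc(CNc2cc(C(F)(F)F)cc3[nH]ncc23)c1`, a limit in an assay for inhibition of Indoleamine 2,3-dioxygenase 1 (Homo sapiens), with stated times of 10 min and 60 min; a higher number here means a weaker inhibitor, a lower number a stronger inhibitor: > 100000 nM
- compound 2 `CNC(=O)c1cccc(CNc2cc(C(F)(F)F)cc3[nH]ncc23)c1`, a limit in this assay: > 100000 nM
- compound 3 `FC(F)(F)c1cc(NC[C@@H]2CCCCN2)c2cn[nH]c2c1`, in this assay: 18700 nM

Within the data shown here, compound 3 is the only compound of the three with a numerical value; the other two values are limits, and compound 1 and compound 2 both sit at the limit of > 100000 nM in this assay, at which 2 of the 3 values shown sit. Among the measured compounds shown here, the one step between measured compounds, a step that the two limits leave unreadable from compound 1 to compound 2, is therefore unreadable in size. Compound 4 `FC(F)(F)c1cc(NCc2cccc(Br)c2)c2cn[nH]c2c1` differs from compound 3 by 3-bromophenyl in place of piperidin-2-yl on a saturated chain carbon bound to a nitrogen on an aromatic ring. For the measured compounds named here, no measured step touches this kind of change, so there is no basis for a direction beyond the scatter. The value of compound 4 is expected to stay near that of compound 3, with the step of a 1.0-fold lower number from compound 3 to compound 4 (0.02 log units; within the scatter) estimated at about no change. Compound 4 is estimated at 18000 nM, within 3000 nM to 90000 nM.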

Compound 4, half-maximal inhibitory concentration: > 100000 nM
Compound 4: a limit, no number; the forecaster's own chance of this, stated with the estimate: 25%; at least 5.5-fold (0.74 log units) between middle value and limit.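

Among these compounds, on the saturated chain carbon bound to a nitrogen on an aromatic ring, 3-bromophenyl in place of piperidin-2-yl gives the only readable step in this assay: an at least 5.3-fold higher number from compound 3 to compound 4 (0.72 log units; beyond the scatter). Among the compounds shown here, compound 3 remains the only compound with a number, while the three compounds with a substituted phenyl ring at this place end at a limit: the limit of > 100000 nM in this assay, at which 3 of the 4 values shown sit. The steps among those three cannot be read, so their bromo, carboxy and methylcarbamoyl groups cannot be ranked.

Open, going by these compounds, is whether the piperidine nitrogen or the saturated ring matters, which a cyclohexyl group or an open-chain amine at this place could separate. On these data alone, the other stereoisomer of the piperidin-2-yl group also remains open.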